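Inverting the chain stereocentre of compound 2

The source may report more compounds than this note shows. Statements on the series, on what has been measured and on what is new or still open speak of the compounds shown alone.

For the measured compounds named here, in a functional assay on KARPAS-422 cells (Homo sapiens) for antiproliferative activity, read by resazurin assay, with a stated time of 72 h (on this read-out higher numbers stand for weaker inhibition and lower numbers for stronger inhibition), compound 2 `Cc1cc(C)c(CN2CCc3c(Cl)cc([C@H](C)CO)c(Cl)c3C2=O)c(=O)[nH]1` gives 186 nM, the only single number in the set. Compound 1 `COC(c1cc(Cl)c2c(c1Cl)C(=O)N(Cc1c(C)cc(C)[nH]c1=O)CC2)C1CCOCC1` gives 1150 nM; 19 nM (2 entries). Compound 3 `Cc1cc(C)c(CN2CCc3c(Cl)cc(C(CO)C4CCOC4)c(Cl)c3C2=O)c(=O)[nH]1` gives 1040 nM; 17 nM (2 entries). The number for compound 2 thus falls inside the spread of each of these two compounds.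

Compound 4 `Cc1cc(C)c(CN2CCc3c(Cl)cc([C@@H](C)CO)c(Cl)c3C2=O)c(=O)[nH]1` differs from compound 2 as follows: the two compounds have the same atoms and bonds and differ only in configuration as drawn: 1 of 1 stereo elements differ; a stereocentre at a saturated chain carbon is drawn S in compound 2 and R in compound 4. A stereocentre at a saturated chain carbon is drawn S in compound 2 and R in compound 4. Going by the values given here, no measured step isolates this change. Compound 1 and compound 3 are both drawn without configuration, and their entries lie far apart (the several entries of compound 1 in this assay, 1150 nM; 19 nM (2 entries); (the several entries of compound 3 in this assay, 1040 nM; 17 nM (2 entries))), which leaves room for a large stereochemical effect, though this is not shown. Compound 2, at 186 nM, sits well above the stronger entries of both, so it may already be the better of its pair.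

A large step towards weaker inhibition in this assay is therefore expected, estimated as a 5.4-fold higher number from compound 2 to compound 4 (0.73 log units; beyond the scatter), with the opposite direction not excluded. For compound 4 the estimated value is 1000 nM, with an expected range of 20 nM to 6000 nM.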

Compound 4, half-maximal inhibitory concentration: 1500 nM
Compound 4: the middle estimate sits 1.5-fold (0.18 log units) below what was measured; low and high end bracket the measured number.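

In this assay, the chain stereocentre now has a measured step, an 8.1-fold higher number from compound 2 to compound 4 (0.91 log units; beyond the scatter), so the S configuration as drawn goes with the stronger inhibition in this pair. Nothing enters or leaves in this step, so the difference can be assigned to configuration alone: the fact that compounds 2 and 4 differ only in the configuration as drawn. The earlier compounds with a branched chain are drawn without configuration, so their wide entries could only leave room for such an effect, as seen in: the several entries of compound 3 in this assay, 1040 nM; 17 nM (2 entries)

On these data alone, whether the S preference survives when a primary amine or a carboxylic acid replaces the hydroxyl group of the chain stays open. Also open, as far as these compounds go, is how the separate entries of compound 1 and compound 3 relate to their configurations, and whether either configuration there repeats the preference seen here.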